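The source may hold more compounds than are shown below. What is called first, only, known or untested is meant among the compounds shown, and "the series" means these compounds.

In a physicochemical assay for lipophilicity, read by LC-MS, in phosphate buffer, measured as octanol-water partition, with a stated time of 30 min, at pH 7.4, tested at 200 mM (a higher number here means a more lipophilic compound, a lower number a more polar compound), compound 1 `Cn1c(COc2cccc(C(=O)O)c2)nc2ccc(Oc3ccc4c(c3)CCC4)nc21` gives 2.5, while compound 2 `Cn1c(COc2cccc(C(=O)O)c2)nc2ccc(Oc3cc(Cl)ccn3)cc21` gives 1.2, the lower of the two values, with compound 1 standing higher by a gap beyond the usual scatter. Going by the values given here, no pair of measured compounds differs in just one place, so no single step has yet been measured. Compound 3 `Cc1ccc(C)c(Oc2ccc3nc(COc4cccc(C(=O)O)c4)n(C)c3c2)n1` differs from compound 2 by 3,6-dimethylpyridin-2-yl in place of 4-chloropyridin-2-yl on an oxygen on an aromatic ring. A modest upward step in this assay is expected here, a number 0.40 log units higher from compound 2 to compound 3 (beyond the scatter). Compound 3 is accordingly estimated at 1.6, with a likely range from 1.1 to 2.1.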

Compound 3, distribution coefficient: 1.4
Estimate against measurement, compound 3: 0.20 log units above, and the stated range covers the measured number.
By their numbers in this assay, from the lowest: compounds 2 and 3 (each within the scatter of the next); then compound 1.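

In this assay, 3,6-dimethylpyridin-2-yl in place of 4-chloropyridin-2-yl on an oxygen on an aromatic ring gives a number 0.20 log units higher from compound 2 to compound 3 (within the scatter), the first single step read at this position. This measurement therefore does not tell these two groups apart. Nothing at hand offers an explanation for this result.

The compounds shown leave open whether an amine or a longer alkyl chain on this pyridine ring would give a step beyond the scatter. They also leave open how a single methyl group on this ring would read.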